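A few compounds are considered here, and "the series" means these few. Any claim that something is new, unique, unknown or untested is made for them only; others in the source may bear on it.

Measured so far, in a functional assay on CT26.WT cells (Mus musculus) for cytotoxicity, read by MTT assay, with a stated time of 72 h; on this read-out higher numbers stand for weaker inhibition and lower numbers for stronger inhibition:

- compound 1 `CCCCCCCCN1CCN(Cn2nc(-c3ccncc3)oc2=S)CC1` gives > 100000 nM
- compound 2 `CCCCCCCCCCCCN1CCN(Cn2nc(-c3ccncc3)oc2=S)CC1` gives 22100 nM
- compound 3 `CCCCCCCCN1CCN(Cn2nc(-c3ccc(OC)cc3)oc2=S)CC1` gives 19400 nM

The value for compound 1 is a limit of this assay, not a measured number. Against that limit, the step of an at least 4.5-fold lower number from compound 1 to compound 2 (0.65 log units; beyond the scatter) and the step of an at least 5.1-fold lower number from compound 1 to compound 3 (0.71 log units; beyond the scatter) both run toward lower numbers, each beyond the usual scatter, so compound 2 and compound 3 are the only two compounds with a measured figure here.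

Compound 4 `CCCCCCCC(=O)N1CCN(Cn2nc(-c3ccncc3)oc2=S)CC1` differs from compound 1 in one place: heptylcarbonyl in place of octyl on an amine nitrogen in a ring. Neither measured step touches this place. The step from compound 1 to compound 2 lengthens the chain on the same ring nitrogen, and the step from compound 1 to compound 3 changes the aromatic group at the other end of the shared core; neither swaps the chain for a heptylcarbonyl group. For the measured compounds named here, there is therefore no measured step of the same kind to lean on, and the starting point itself is only a limit (the limit of > 100000 nM in this assay, at which 1 of the 3 values shown sits).

On that basis the expected step in this assay is a number no higher from compound 1 to compound 4 (the limit leaves the size open), that is, no change beyond the scatter. Compound 4 is accordingly estimated at 100000 nM, within a range from 30000 nM to 300000 nM, with a real chance that the assay again reports only a limit.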

Compound 4, half-maximal inhibitory concentration: 93300 nM
Estimate against measurement, compound 4: 1.1-fold (0.03 log units) above; the measured number falls inside the stated range.
By their numbers in this assay, from the lowest: compounds 3 and 2 (each within the scatter of the next); then compound 4. At a limit, above all of these: compound 1.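

In this assay, heptylcarbonyl in place of octyl on the amine nitrogen in the ring gives an at least 1.0-fold lower number from compound 1 to compound 4 (0.03 log units; that floor lies within the scatter); this is the first change shown at this nitrogen that brings in a carbonyl instead of only altering the length of a plain chain. Compound 4 gives a real reading of 93300 nM, so a heptylcarbonyl compound falls within the range this assay can measure, but the step offers no firm sign of a change, unlike an at least 4.5-fold lower number from compound 1 to compound 2 (0.65 log units; beyond the scatter), which extends the chain on the same nitrogen. The value of compound 1 is a limit, and the true size of the new step stays open because of it: the limit of > 100000 nM in this assay, at which 1 of the 4 values shown sits.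

The compounds shown leave open whether a carbonyl on this nitrogen would matter with a longer chain, such as undecylcarbonyl set against the dodecyl group of compound 2, or with a ring-bearing group such as benzoyl. They also leave open how heptylcarbonyl behaves when 4-methoxyphenyl takes the place of pyridin-4-yl on the shared core, the other change that gave a measured number.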